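Ethoxy to methoxy on a ketone chromanone scaffold

The source may hold more compounds than are shown below. What is called first, only, known or untested is meant among the compounds shown, and "the series" means these compounds.

Measured compounds:
compound 1, `COc1ccc([C@@H]2C/C(=N/OCc3cn(-c4ccc(Cl)cc4C)nn3)c3cc(CC=C(C)C)c(OC)cc3O2)cc1`, 35%
compound 2, `CCOc1ccc([C@@H]2CC(=O)c3cc(CC=C(C)C)c(OC)cc3O2)cc1`, 37%
compound 3, `COc1ccc([C@@H]2C/C(=N/OCc3cn(-c4ccc(O)cc4)nn3)c3cc(CC=C(C)C)c(OC)cc3O2)cc1`, 52%

All three were tested in a functional assay on A549 cells (Homo sapiens) for inhibition, read by sulforhodamine B assay, with a stated time of 48 h, tested at 50 uM; on this read-out higher numbers stand for more inhibition of growth at the one concentration tested and lower numbers for less inhibition of growth. Compound 2 stands in the middle of the three numbers: compound 1 lies within the scatter of it, while compound 3 lies beyond it. Going by the values given here, the one measured step is a number 17 percentage points higher from compound 1 to compound 3 (beyond the scatter), on the aromatic nitrogen of the oxime ether series.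

Compound 4, `COc1ccc([C@@H]2CC(=O)c3cc(CC=C(C)C)c(OC)cc3O2)cc1`, differs from compound 2 by hydrogen in place of methyl on a saturated chain carbon bound to an oxygen on an aromatic ring. Among the compounds with values here, no measured step touches this position, and the step from compound 1 to compound 3 concerns a different part of the molecule, so it gives no guidance. With no bearing evidence, no change beyond the scatter is expected. Compound 4 is therefore estimated at 37%, between 25% and 50%, an expected step of no change at the digits printed from compound 2 to compound 4 (within the scatter).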

Compound 4, percent growth inhibition at one concentration: 45%
Estimate against measurement, compound 4: 8 percentage points below; measured number inside the range.
By their numbers in this assay, from the lowest: compounds 1, 2, 4 and 3 (each within the scatter of the next, the first and the last beyond it).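

In this assay, going by these compounds alone, the change from 4-ethoxyphenyl to 4-methoxyphenyl on the ketone compounds gives a number 8 percentage points higher from compound 2 to compound 4 (within the scatter) and so is the first reading at this position. At this single concentration, ethyl and methyl on that oxygen cannot be told apart. No available evidence bears on a cause for this step.

On these data alone, whether the position would accept a much larger or different group stays open, for example a butyl chain or a carboxylic acid on that oxygen. Also open, as far as these compounds go, is whether the same change would read alike on the oxime ether compounds.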